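A few compounds are considered here, and "the series" means these few. Any claim that something is new, unique, unknown or untested is made for them only; others in the source may bear on it.

Measured in a functional assay on the whole organism for inhibition, with Rattus norvegicus as the target, read by paw edema, with stated times of 1 h and 0.5 h, at a dose of 100 mg/kg by the oral route; a lower number here means less inhibition, a higher number more inhibition at the dose given (going by the name of the read-out):
compound 1, `Cc1ccccc1S(=O)(=O)N1CC(O)C[C@H]1C(=O)Nc1ccc(C(=O)O)cc1`, gives 38.6%
compound 2, `O=C(O)c1ccc(NC(=O)[C@@H]2CC(O)CN2S(=O)(=O)c2ccc([N+](=O)[O-])cc2)cc1`, gives 44.1%

Within the data shown here, only two numbers are known so far, and they do not separate: the single step between them, 4-nitrophenyl in place of 2-methylphenyl on the sulfonyl sulfur, reads a number 5.5 percentage points higher from compound 1 to compound 2 (within the scatter). Compound 2 thus stands with compound 1 rather than apart from it, and no ranking of the two is supported.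

Compound 3, `Cc1ccc(S(=O)(=O)N2CC(O)C[C@H]2C(=O)Nc2ccc(C(=O)O)cc2)cc1`, is not yet measured. It differs from compound 2 in one place: methyl in place of nitro on an aromatic carbon. Among the measured compounds shown here, the only measured step that bears on this change is the one between compound 1 and compound 2, where a methyl-bearing phenyl gave way to a nitro-bearing phenyl on the same sulfonyl sulfur, with a number 5.5 percentage points higher from compound 1 to compound 2 (within the scatter) as the outcome. The present step carries the nitro out and a methyl back in, and there is no further comparison to draw on. The expected step in this assay is therefore none beyond the scatter, a number 4.1 percentage points lower from compound 2 to compound 3 (within the scatter). Compound 3 is estimated at 40%, with a range from 25% to 55%.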

Compound 3, a percentage reported as inhibition, in the whole organism at one dose (the size of the read-out at that dose, not a potency): 58%
Estimate against measurement, compound 3: 18 percentage points below, outside the stated range (above it).
By their numbers in this assay, from the lowest: compounds 1 and 2 (each within the scatter of the next); then compound 3.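

Changing the group on the sulfonyl sulfur can move the read-out in this assay beyond the scatter: methyl in place of nitro gives a number 13.9 percentage points higher from compound 2 to compound 3 (beyond the scatter) and 4-methylphenyl in place of 2-methylphenyl gives a number 19.4 percentage points higher from compound 1 to compound 3 (beyond the scatter) with both steps modest. Both steps end at compound 3, so 4-methylphenyl stands apart from both 4-nitrophenyl and 2-methylphenyl, whereas the earlier step, a number 5.5 percentage points higher from compound 1 to compound 2 (within the scatter), gave no such separation. In these three compounds, both the identity of the group para to a large group and the place of the methyl on the aromatic ring matter to the read-out, but nothing measured here accounts for either step.

How an amine, a methoxy group or a longer chain such as ethyl would read at that same place remains open, so the compounds shown do not tell whether methyl is special there. Also open, as far as these compounds go, is whether the separation of compound 3 from compound 1 and compound 2 would hold at other doses, as each compound is read at a single dose.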